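The source may hold more compounds than are shown below. What is called first, only, known or untested is meant among the compounds shown, and "the series" means these compounds.

Measured in an ADME assay on HEK293 cells (Homo sapiens) for cytotoxicity, read by MTT assay, with a stated time of 72 h; on this read-out higher numbers stand for weaker inhibition and lower numbers for stronger inhibition:
- Compound 1 `COc1ccc2[nH]cc(CCCN3CCN(C(=O)CN4CCN(C(=O)c5cccc(Cl)c5)CC4)CC3)c2c1`: 143000 nM
- Compound 2 `COc1ccc2[nH]cc(CCCN3CCN(C(=O)CN4CCN(C(=O)c5cccc(F)c5)CC4)CC3)c2c1`: > 200000 nM

Compound 2 stands at the limit of > 200000 nM in this assay, at which 1 of the 2 values shown sits, and its reading is a limit, not a number. Compound 3 `COc1ccc2[nH]cc(CCCN3CCN(C(=O)CN4CCN(C(=O)c5ccccc5Br)CC4)CC3)c2c1` carries 2-bromophenyl in place of 3-fluorophenyl on a carbonyl carbon. For the measured compounds named here, the one measured step that bears on this change, fluoro in place of chloro, is an at least 1.3-fold higher number from compound 1 to compound 2 (0.14 log units; that floor lies within the scatter). That step gives no firm size, so compound 1 at 143000 nM serves as the nearest real number, and a modest move toward lower numbers in this assay is expected. The expected step is an at least 1.5-fold lower number from compound 2 to compound 3 (0.18 log units; that floor lies within the scatter). Compound 3 is estimated at 130000 nM, with an expected range of 60000 nM to 250000 nM.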

Compound 3, half-maximal inhibitory concentration: 163000 nM
For compound 3 the middle estimate is 1.3-fold (0.10 log units) below the measured one, and the stated range covers the measured number.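

In this assay, 2-bromophenyl in place of 3-chlorophenyl on this carbonyl carbon gives a 1.1-fold higher number from compound 1 to compound 3 (0.06 log units; within the scatter), so the two groups are not told apart here. Against 3-fluorophenyl, the step is an at least 1.2-fold lower number from compound 2 to compound 3 (0.08 log units; that floor lies within the scatter). The reading of compound 2 remains a limit, not a number: the limit of > 200000 nM in this assay, at which 1 of the 3 values shown sits.

The compounds shown do not separate the identity of the halogen from its place on the ring, which 3-bromophenyl or 2-chlorophenyl would address. As far as these compounds go, how a phenyl ring bearing an amine or a carboxylic acid would read here also remains open.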